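Alkyne Aryl Swap: Pyrimidine Replaced by a Methylpyrazole

A few compounds are considered here, and "the series" means these few. Any claim that something is new, unique, unknown or untested is made for them only; others in the source may bear on it.

Compound 1 `CNC(=O)[C@@]12C[C@@H]1[C@@H](n1cnc3c(NC)nc(C#Cc4ccccc4F)nc31)[C@H](O)[C@@H]2O` gives 20% in an assay on CHO cells for displacement of a labelled ligand from adenosine receptor A1 (Homo sapiens), read by scintillation counting, with a stated time of 60 min, tested at 10 uM; a lower number here means less inhibition, a higher number more inhibition at the concentration tested (going by the name of the read-out). Compound 2 `CNC(=O)[C@@]12C[C@@H]1[C@@H](n1cnc3c(NC)nc(C#Cc4cccc(C(F)(F)F)c4)nc31)[C@H](O)[C@@H]2O` gives 10%. Compound 3 `CNC(=O)[C@@]12C[C@@H]1[C@@H](n1cnc3c(NC)nc(C#Cc4ncccn4)nc31)[C@H](O)[C@@H]2O` gives 25%.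

Compound 3 holds the highest of the three numbers, though only its gap to compound 2 is beyond the scatter: a number 15 percentage points higher from compound 2 to compound 3 (beyond the scatter), whereas a number 5 percentage points higher from compound 1 to compound 3 (within the scatter). Compound 4 `CNC(=O)[C@@]12C[C@@H]1[C@@H](n1cnc3c(NC)nc(C#Cc4cnn(C)c4)nc31)[C@H](O)[C@@H]2O` is the next variation, with 1-methyl-1H-pyrazol-4-yl in place of pyrimidin-2-yl on a triple-bonded carbon.

Going by the values given here, no measured step involves either of these two groups, so the bearing of the earlier steps is indirect. All three steps swap the group on the triple-bonded carbon, and they move the read-out by at most a modest amount (a number 10 percentage points lower from compound 1 to compound 2 (within the scatter), a number 15 percentage points higher from compound 2 to compound 3 (beyond the scatter)). A comparable swap is therefore expected to stay near compound 3, with a number 3 percentage points lower from compound 3 to compound 4 (within the scatter). Compound 4 is expected to give 22%, with a range from 5% to 40%.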

Compound 4, a percentage reported as inhibition, at one concentration (the size of the read-out at that concentration, not a potency): 35%
Compound 4: the middle estimate sits 13 percentage points below what was measured, within the range that was stated.
By their numbers in this assay, from the lowest: compounds 2, 1, 3 and 4 (each within the scatter of the next, the first and the last beyond it).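

In this assay, the five-membered 1-methyl-1H-pyrazol-4-yl cannot be separated from the six-membered pyrimidin-2-yl, with a number 10 percentage points higher from compound 3 to compound 4 (within the scatter). Going by these compounds alone, it is nevertheless the first group on the triple-bonded carbon to stand clear of both phenyl groups, with a number 25 percentage points higher from compound 2 to compound 4 (beyond the scatter) and a number 15 percentage points higher from compound 1 to compound 4 (beyond the scatter), whereas compound 3 stands clear only of compound 2. Nothing available explains these steps.

On these data alone, whether the methyl on the pyrazole contributes remains open, as a pyrazole bearing a hydrogen or an ethyl there would test. So does the effect of an amine or a carboxylic acid on the ring.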